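The source may report more compounds than this note shows. Statements on the series, on what has been measured and on what is new or still open speak of the compounds shown alone.

Of the compounds shown here, three sharing one core have been tested in a functional assay on HeLa cells (Homo sapiens) for antiproliferative activity, with a stated time of 24 h; a lower number here means a stronger inhibitor, a higher number a weaker inhibitor. Compound 1, `NC(=O)c1c(NC(=O)c2ccccc2)sc2c1CCN(C(=S)Nc1ccccc1Cl)C2`, carries hydrogen on an aromatic carbon. In this assay compound 1 gives > 50000 nM, which is a limit of the assay and not a number. Compound 2, `NC(=O)c1c(NC(=O)c2ccccc2Br)sc2c1CCN(C(=S)Nc1ccccc1Cl)C2`, has bromo in place of that hydrogen. In this assay compound 2 gives 46900 nM. Compound 3, `NC(=O)c1c(NC(=O)c2ccccc2I)sc2c1CCN(C(=S)Nc1ccccc1Cl)C2`, has iodo in place of the hydrogen. In this assay compound 3 gives > 50000 nM, again a limit rather than a number. The measured steps are an at least 1.0-fold lower number from compound 1 to compound 2 (0.02 log units; that floor lies within the scatter) and an at least 1.0-fold higher number from compound 2 to compound 3 (0.02 log units; that floor lies within the scatter), while the step that the two limits leave unreadable from compound 1 to compound 3 cannot be read. All three values thus sit at or close to the limit of > 50000 nM in this assay, at which 2 of the 3 values shown sit. Compound 4, `NC(=O)c1c(NC(=O)c2ccccc2C(F)(F)F)sc2c1CCN(C(=S)Nc1ccccc1Cl)C2`, differs from compound 3 by trifluoromethyl in place of iodo on an aromatic carbon. The bromo and iodo steps measured so far moved nothing beyond the scatter, so no change beyond the scatter is expected from this swap either, and the expected step is a number no higher from compound 3 to compound 4 (the limit leaves the size open). Compound 4 is therefore estimated at 50000 nM, within a range of 20000 nM to 120000 nM.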

Compound 4, half-maximal inhibitory concentration: 46900 nM
Beside the measured number, compound 4's estimate is 1.1-fold (0.03 log units) above it, within the range that was stated.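

In this assay, a group of 4 heavy atoms in place of 1 still moves nothing beyond the scatter, which extends the flat result at this position from single halogen atoms to a larger group: the steps read an at least 1.0-fold lower number from compound 3 to compound 4 (0.02 log units; that floor lies within the scatter), no change at the digits printed from compound 2 to compound 4 (within the scatter) and an at least 1.0-fold lower number from compound 1 to compound 4 (0.02 log units; that floor lies within the scatter). Hydrogen, bromo, iodo and trifluoromethyl therefore cannot be told apart here. All four compounds stay at or close to one edge of what this read-out can show: the limit of > 50000 nM in this assay, at which 2 of the 4 values shown sit.

Going by these compounds, what an amine or a carboxylic acid at this position would do remains open, as does whether any group here can bring the number clear of that limit. With all four values so near the limit, the compounds shown cannot rank these groups.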